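The source may hold more compounds than are shown below. What is called first, only, known or untested is meant among the compounds shown, and "the series" means these compounds.

The study concerns a shared core that carries a substituted phenyl on an amide-type nitrogen. Compound 1 `Cc1cccc(C)c1NC(=O)CSc1nnc(-c2ccoc2C)n1Cc1ccco1` and compound 2 `Cc1cccc(NC(=O)CSc2nnc(-c3ccoc3C)n2Cc2ccco2)c1C` are the two measured examples. In a functional assay on CHO cells for antagonist activity at Orexin/Hypocretin receptor type 1 (Homo sapiens), read by FLIPR and calcium flux (on this read-out lower numbers stand for stronger inhibition and higher numbers for weaker inhibition), compound 1 reaches only the limit of the assay, > 15800 nM. In this assay compound 2 likewise reaches only a limit, > 15800 nM. Within the data shown here, the one measured step, a step that the two limits leave unreadable from compound 1 to compound 2, therefore cannot be read as a number in either direction. Both values sit at the limit of > 15800 nM in this assay, at which 2 of the 2 values shown sit, so nothing about the size of any change on this nitrogen can be taken from them.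

Compound 3 `Cc1ccc(NC(=O)CSc2nnc(-c3ccoc3C)n2Cc2ccco2)cc1` differs from compound 2 by 4-methylphenyl in place of 2,3-dimethylphenyl on an amide-type nitrogen. Among the measured compounds shown here, no measured step with a readable size bears on this change. Because compound 2 shows only the limit > 15800 nM, the expectation for compound 3 rests on that limit alone. Compound 3 is expected to give an estimated 30000 nM in this assay, with a range from 8000 nM to 120000 nM, most likely again reported as a limit. The expected step that the limit leaves unreadable from compound 2 to compound 3 is an estimate and is not expected to exceed the scatter.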

Compound 3, inhibition constant: > 15800 nM
Compound 3: no number, only a limit (the forecaster's own chance of this, stated with the estimate: 85%); the middle value lies beyond the limit too.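

Compound 3 gives only a limit in this assay, > 15800 nM. The steps among compound 1, compound 2 and compound 3 therefore cannot be read: the limit of > 15800 nM in this assay, at which 3 of the 3 values shown sit. The compounds shown leave open whether any substituted phenyl on this amide-type nitrogen gives a measurable inhibition constant, and how large any difference between these groups would be.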